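Shifting the Chlorine on the Benzamide: Compound 3 to 4

A few compounds are considered here, and "the series" means these few. Any claim that something is new, unique, unknown or untested is made for them only; others in the source may bear on it.

Measured so far, in an assay on isolated protein for inhibition of RAC-alpha serine/threonine-protein kinase (Homo sapiens), read by fluorescence, with a stated time of 30 min, tested at 10 uM; a higher number here means more inhibition at the concentration tested (going by the name of the read-out), a lower number less inhibition:
- compound 1, `O=C(/C=C/c1ccc([N+](=O)[O-])cc1)Nc1cc(Sc2ncn[nH]2)c(O)c2ccccc12`, gives 40.6%
- compound 2, `Cc1nnc(Sc2cc(NC(=O)c3ccc(Cl)cc3)c3ccccc3c2O)s1`, gives 8.48%
- compound 3, `O=C(Nc1cc(Sc2ncn[nH]2)c(O)c2ccccc12)c1cccc(Cl)c1`, gives 46%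

All three share a naphthol core carrying a thiol-linked heterocycle and an amide. Compound 3 holds the highest of the three numbers. Its nearest neighbour is compound 1, whose value sits within the scatter of repeated measurements, so the two cannot be told apart. Compound 2, which carries a different heterocycle on the sulfur, lies far lower, well beyond the scatter.

Compound 4, `O=C(Nc1cc(Sc2ncn[nH]2)c(O)c2ccccc12)c1ccc(Cl)cc1`, has not yet been measured. It differs from compound 3 in one place only: 4-chlorophenyl in place of 3-chlorophenyl on a carbonyl carbon. The same atoms are present, joined differently. Going by the values given here, no measured pair in this set shows exactly this change on the shared core, so there is no direct step to lean on. Compound 2 does carry the 4-chlorophenyl group, but on another heterocycle, so its low value is only a weak hint.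

Given this, the expected step of a number 11 percentage points lower from compound 3 to compound 4 (beyond the scatter) is small and, if anything, downward, and it may not exceed the scatter. Compound 4 is estimated at 35%, within a range from 10% to 58%.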

Compound 4, a percentage reported as inhibition, at one concentration (the size of the read-out at that concentration, not a potency): 50.1%
Compound 4: the middle estimate sits 15.1 percentage points below what was measured; the range from low to high includes it.
By their numbers in this assay, from the lowest: compound 2; then compounds 1, 3 and 4 (each within the scatter of the next).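

In this assay, exchanging 3-chlorophenyl for 4-chlorophenyl on a carbonyl carbon gives a number 4.1 percentage points higher from compound 3 to compound 4 (within the scatter), so at this position the two placements of the chlorine cannot be told apart on the triazole-bearing core. With 4-chlorophenyl now common to both compounds, the group on the sulfur can be read on its own: 1H-1,2,4-triazol-5-yl in place of 5-methyl-1,3,4-thiadiazol-2-yl gives a number 41.6 percentage points higher from compound 2 to compound 4 (beyond the scatter), which shows that the low number of compound 2 goes with its group on the sulfur and not with its 4-chlorophenyl. No measurement at hand explains the size of either step.

On these data alone, it remains open whether the chlorine matters at all, since a plain phenyl, a methoxyphenyl or a pyridine ring on the carbonyl carbon could read like compound 3 and compound 4 or quite differently. Going by these compounds alone, on the sulfur, only two groups can be compared so far, which leaves open how an imidazole, a tetrazole or a simple methyl group would compare with the 1H-1,2,4-triazol-5-yl group.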